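The source may report more compounds than this note shows. Statements on the series, on what has been measured and on what is new or still open speak of the compounds shown alone.

Measured in a functional assay on B16 cells (Mus musculus) for cytotoxicity, read by MTT assay, with a stated time of 48 h; a lower number here means a stronger inhibitor, a higher number a weaker inhibitor:
Compound 1 `C#CCNC(=O)c1cn(CCOC(C)=O)nn1`: > 100000 nM, a limit
Compound 2 `C#Cc1cccc(NC(=O)c2cn(CCOC(C)=O)nn2)c1`: 25100 nM
Compound 3 `CCOC(=O)Cn1cc(C(=O)Nc2ccccc2)nn1`: > 100000 nM, a limit

Only compound 2 gives a number in this assay. Compound 3 gives no number, only a limit, and it shares that position with compound 1: the limit of > 100000 nM in this assay, at which 2 of the 3 values shown sit.

The next compound to be tested is compound 4 `CC(=O)OCCn1cc(C(=O)Nc2ccccc2)nn1`, which has the same atoms as compound 3, joined differently. The change is acetoxymethyl in place of ethoxycarbonyl on a saturated chain carbon bound to an aromatic nitrogen. In words, acetoxymethyl takes the place of ethoxycarbonyl on a saturated chain carbon bound to an aromatic nitrogen. Cut one bond further out, this reads as (ethoxycarbonyl)methyl to 2-acetoxyethyl.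

Among the measured compounds shown here, no measured pair shows this change directly, so the expectation rests on compound 3 and its limit of > 100000 nM. The expected step, an at least 1.1-fold lower number from compound 3 to compound 4 (0.04 log units; that floor lies within the scatter), is estimated to stay within the usual scatter, with no clear direction. A limit rather than a number would be no surprise. For compound 4 the estimated value is 90000 nM, with an expected range from 35000 nM to 200000 nM.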

Compound 4, half-maximal inhibitory concentration: > 100000 nM
Compound 4: a limit, no number; the forecaster's own chance of this, stated with the estimate: 65%; middle value at least 1.1-fold (0.04 log units) from the limit.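

In this assay the steps from compound 3 and from compound 1 to compound 4 cannot be read: each pair ends in two limits, so the change to acetoxymethyl in place of ethoxycarbonyl shows no effect in either direction. Among the compounds shown here, the one readable comparison is new: hydrogen in place of ethynyl on an aromatic carbon gives an at least 3.9-fold higher number from compound 2 to compound 4 (0.60 log units; beyond the scatter), so with the 2-acetoxyethyl chain held fixed, the ethynyl group separates a measured value from a limit. The limit is now the common outcome in this assay: the limit of > 100000 nM in this assay, at which 3 of the 4 values shown sit.

On these data alone, whether a nitrile or a chlorine atom on that aromatic carbon would also give a number remains open. So does how (ethoxycarbonyl)methyl compares with 2-acetoxyethyl when ethynyl is present, the setting in which that change could be read against a number.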